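This account rests on a few compounds, and the source may have more. Where it says the series, first, only, none or still open, it means among the compounds named here.

Among the measured compounds shown here, compound 3, `CCCc1nc(-c2ccccc2)c(CNCCN2CCN(c3cccc(Cl)c3)CC2)o1`, gives 51.2% in an assay on HEK293 cells for inhibition of Voltage-dependent T-type calcium channel subunit alpha-1G (Homo sapiens), read by fluorescence, tested at 10 uM (on this read-out lower numbers stand for less inhibition and higher numbers for more inhibition at the one concentration tested (going by the name of the read-out)), the lowest of the three numbers so far; compound 1, `CCCc1nc(-c2ccccc2)c(CNCCN2CCN(c3ccc(Cl)cc3)CC2)o1`, gives 55.8%, within the scatter of it, and compound 2, `CCCc1nc(-c2ccccc2)c(CNCCN2CCN(c3cccc(C)c3C)CC2)o1`, gives 66.7%. The step of a number 4.6 percentage points lower from compound 1 to compound 3 (within the scatter) and the step of a number 15.5 percentage points lower from compound 2 to compound 3 (beyond the scatter) are the measured changes of the group on the ring nitrogen, so exchanging that aryl group has shifted this assay by modest amounts at most. Compound 4, `CCCc1nc(-c2ccccc2)c(CNCCN2CCN(c3ccccc3OC)CC2)o1`, carries 2-methoxyphenyl in place of 3-chlorophenyl on an amine nitrogen in a ring. For the measured compounds named here, no measured compound bears a 2-methoxyphenyl, so only a small to modest step is expected, more likely upward given that compound 3 stands lowest at 51.2%. The expected step of a number 6.8 percentage points higher from compound 3 to compound 4 (within the scatter) is therefore small. Compound 4 is estimated at 58%, with a range of 44% to 72%.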

Compound 4, a percentage reported as inhibition, at one concentration (the size of the read-out at that concentration, not a potency): 39.7%
Compound 4: the middle estimate sits 18.3 percentage points above what was measured; measured number below the stated range.
By their numbers in this assay, from the lowest: compound 4; then compounds 3 and 1 (each within the scatter of the next); then compound 2.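

In this assay, the group on the ring nitrogen moves the read-out further than the two chlorophenyl compounds suggested: a number 11.5 percentage points lower from compound 3 to compound 4 (beyond the scatter), a number 16.1 percentage points lower from compound 1 to compound 4 (beyond the scatter) and a number 27 percentage points lower from compound 2 to compound 4 (beyond the scatter). The 2-methoxyphenyl compound therefore stands lowest of the four, and this position is clearly sensitive to the aryl group it carries. Nothing available gives a reason for the drop. Going by these compounds, it remains open whether a plain phenyl, a 2-chlorophenyl or a 2-ethoxyphenyl on the same nitrogen would read as low, which would help separate the effect of the methoxy group from that of its place on the ring.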